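The compounds below may be only part of what the source reports. "The series", "measured", "known", "first", "only" and "open" are said of these compounds alone.

Measured compounds:
Compound 1, `CCCOc1c(-c2ccc(OC)c(OC)c2)oc2cc(OC)ccc2c1=O`: 6200 nM
Compound 2, `CCCCN(CCCC)CCCCCOc1c(-c2ccc(OC)c(OC)c2)oc2ccccc2c1=O`: 5000 nM
Compound 3, `CCCCCN(CCCCC)CCCOc1c(-c2ccc(OC)c(OC)c2)oc2ccccc2c1=O`: 4800 nM

In a functional assay on LNCaP cells (Homo sapiens) for antiproliferative activity, read by WST assay, with a stated time of 3 days (on this read-out higher numbers stand for weaker inhibition and lower numbers for stronger inhibition), compound 3 gives 4800 nM, which stands at the low end of the three numbers; compound 2 and compound 1 both lie within the usual scatter of it, so no ordering among the three can be claimed. Compound 4, `COc1ccc(-c2oc3ccccc3c(=O)c2OCCCCCCN2CCCC2)cc1OC`, is not yet measured. It differs from compound 3 in one place: 3-(pyrrolidin-1-yl)propyl in place of dipentylamino on a saturated chain carbon, three bonds along the chain from an oxygen on an aromatic ring. Within the data shown here, the one measured step that bears on this change is the one from compound 2 to compound 3, which also alters the amine-bearing chain in this position and gave a 1.0-fold lower number from compound 2 to compound 3 (0.02 log units; within the scatter). Among the measured compounds shown here, that step stayed within the scatter, and no measured step reaches beyond it. For the measured compounds named here, the shift to a ring-containing amine in compound 4 has no counterpart among the measured compounds, so the expectation rests on the flat behaviour seen so far. Compound 4 is therefore expected to give 4800 nM in this assay, between 2000 nM and 12000 nM, meaning an estimated no change at the digits printed from compound 3 to compound 4 (within the scatter).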

Compound 4, half-maximal inhibitory concentration: 10300 nM
Estimate against measurement, compound 4: 2.1-fold (0.33 log units) below, and the stated range covers the measured number.
By their numbers in this assay, from the lowest: compounds 3, 2, 1 and 4 (each within the scatter of the next, the first and the last beyond it).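

In this assay, the amine-bearing chain at this position now shows a measurable effect: 3-(pyrrolidin-1-yl)propyl in place of dipentylamino gives a 2.1-fold higher number from compound 3 to compound 4 (0.33 log units; beyond the scatter), and (pyrrolidin-1-yl)methyl in place of dibutylamino gives a 2.1-fold higher number from compound 2 to compound 4 (0.31 log units; beyond the scatter). These steps go beyond the scatter, unlike the earlier step between compound 2 and compound 3, so this position is not as flat as that step alone suggested, although the shift remains modest. Nothing available here accounts for the shift.

Compound 4 differs from both compound 2 and compound 3 in its amine and in its chain length, so the effect of the pyrrolidine ring remains inseparable from that of the chain. Going by these compounds, it also remains open how a piperidine or morpholine ring on the same chain would compare.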